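Removing the fluoro group from compound 2

The source may hold more compounds than are shown below. What is called first, only, known or untested is meant among the compounds shown, and "the series" means these compounds.

Values in a functional assay on KB cells (Homo sapiens) for cytotoxicity; a lower number here means a stronger inhibitor, a higher number a weaker inhibitor:
- Compound 1 `COc1ccc(S(=O)(=O)N2CCc3cccc(NC(=O)c4cccs4)c32)cc1`: 43 nM
- Compound 2 `COc1ccc(S(=O)(=O)N2CCc3cccc(NC(=O)c4ccc(F)cc4)c32)cc1`: 85 nM

Among the measured compounds shown here, compound 2 stands within the scatter of compound 1, the only other measured compound. Compound 3 `COc1ccc(S(=O)(=O)N2CCc3cccc(NC(=O)c4ccccc4)c32)cc1` is still to be measured. The change leading to it from compound 2 is hydrogen in place of fluoro on an aromatic carbon, para to a large group. For the measured compounds named here, no measured pair isolates this fluoro group. Going by the values given here, the one available step, which puts 4-fluorophenyl in place of thiophen-2-yl on the same carbonyl carbon, is a 2.0-fold higher number from compound 1 to compound 2 (0.30 log units; within the scatter). It bears only indirectly, but it gives no reason to expect a large change, so no step beyond the scatter is expected in this assay. The expected step is a 1.2-fold lower number from compound 2 to compound 3 (0.08 log units; within the scatter). Compound 3 is estimated at 70 nM, with an expected range of 30 nM to 170 nM.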

Compound 3, half-maximal inhibitory concentration: 180 nM
Estimate against measurement, compound 3: 2.6-fold (0.41 log units) below, and the stated range ends below it.
By their numbers in this assay, from the lowest: compounds 1 and 2 (each within the scatter of the next); then compound 3.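

In this assay, the fluoro group para to a large group now has a measured step of its own: hydrogen in its place gives a 2.1-fold higher number from compound 2 to compound 3 (0.33 log units; beyond the scatter) and so takes the series modestly beyond the scatter. Phenyl on the same carbonyl carbon also separates from thiophen-2-yl, with a 4.2-fold higher number from compound 1 to compound 3 (0.62 log units; beyond the scatter) as the wider step, whereas 4-fluorophenyl and thiophen-2-yl lie within the scatter of each other. No measurement at hand gives a reason for these steps.

On these data alone, whether the step follows fluoro alone or would also appear with a chloro, methyl or amine group at this position stays open. Also open, as far as these compounds go, is whether a substituent on the thiophene ring would give a comparable step, since the fluoro-to-hydrogen change is read on the benzoyl amide only.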